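The source may hold more compounds than are shown below. What is called first, only, known or untested is meant among the compounds shown, and "the series" means these compounds.

Measured in an ADME assay on the whole organism (Rattus norvegicus, strain Lewis) for metabolic stability, at a dose of 2 mg/kg by the oral route; on this read-out lower numbers stand for a shorter-lived compound and higher numbers for a longer-lived compound:

- compound 1 `N[C@]1(CO)CC[C@H](c2ccc3c(c2)CC[C@@H](COc2ccc(F)cc2)C3)C1`: 46 h
- compound 2 `COc1ccc(OC[C@@H]2CCc3cc([C@H]4CC[C@](N)(CO)C4)ccc3C2)cc1`: < 10 h (a limit of the assay, not a number)
- compound 3 `COc1ccccc1SC[C@@H]1CCc2cc([C@H]3CC[C@](N)(CO)C3)ccc2C1`: 24 h

Compound 1, at 46 h, stands level with compound 3 within the scatter, and only compound 2 is clearly separated from it.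

The next compound is compound 4 `COc1cccc(OC[C@@H]2CCc3cc([C@H]4CC[C@](N)(CO)C4)ccc3C2)c1`. Its difference from compound 1 is 3-methoxyphenyl in place of 4-fluorophenyl on an oxygen on a saturated carbon, in words 3-methoxyphenyl in place of 4-fluorophenyl on an oxygen on a saturated carbon.

Within the data shown here, two measured steps bear on this change. Methoxy in place of fluoro on an aromatic carbon gave an at least 4.6-fold lower number from compound 1 to compound 2 (0.66 log units; beyond the scatter). A change to (2-methoxyphenyl)sulfanyl gave a 1.9-fold lower number from compound 1 to compound 3 (0.28 log units; within the scatter). Neither step points upward, and compound 4 keeps the oxygen link found in compound 2, so a drop beyond the scatter is expected in this assay, given an at least 4.6-fold lower number from compound 1 to compound 2 (0.66 log units; beyond the scatter). The expected change is a 3.8-fold lower number from compound 1 to compound 4 (0.58 log units; beyond the scatter). For compound 4 the estimate is 12 h, with an expected range of 5 h to 26 h.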

Compound 4, half-life: 24 h
Beside the measured number, compound 4's estimate is 2.0-fold (0.30 log units) below it, within the range that was stated.
By their numbers in this assay, from the lowest: compounds 3, 4 and 1 (each within the scatter of the next). At a limit, below all of these: compound 2.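

In this assay, a methoxy group on the aryl ether does not by itself bring the long half-life down: 3-methoxyphenyl in place of 4-fluorophenyl gives a 1.9-fold lower number from compound 1 to compound 4 (0.28 log units; within the scatter) at this position, and 3-methoxyphenoxy in place of (2-methoxyphenyl)sulfanyl gives no change at the digits printed from compound 3 to compound 4 (within the scatter) on the same chain carbon. Where the methoxy group stands on the ring does separate two compounds, as 3-methoxyphenyl in place of 4-methoxyphenyl gives an at least 2.4-fold higher number from compound 2 to compound 4 (0.38 log units; beyond the scatter) on this oxygen. Compound 2 sits at a limit of the assay, not at a number: the limit of < 10 h in this assay, at which 1 of the 4 values shown sits.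

On these data alone, the full size of that last step stays open, as does the reading for a sulfur link carrying 3-methoxyphenyl. As far as these compounds go, it is also open how a nitrile or a trifluoromethyl group would read in place of the methoxy group on this ring.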